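Cytotoxicity notes on an amide substituent swap

The compounds below may be only part of what the source reports. "The series", "measured", "known", "first", "only" and "open" are said of these compounds alone.

Compound 1 `O=C(CCSc1nnc(-c2ccncc2)s1)NCc1ccccc1Cl` and compound 2 `CC(CSc1nnc(-c2ccncc2)s1)C(=O)NCc1ccccc1Cl` share one core. In an ADME assay on BHK-21 cells (Mesocricetus auratus) for cytotoxicity, with a stated time of 3 days (a lower number here means that less compound is tolerated, a higher number that more compound is tolerated), compound 1 gives > 50000 nM, which is a limit of the assay. In this assay compound 2 gives > 50000 nM, likewise a limit. The step that the two limits leave unreadable from compound 1 to compound 2 is therefore not readable. Compound 2 thus stands at the limit of > 50000 nM in this assay, at which 2 of the 2 values shown sit. Compound 3 `CC(CSc1nnc(-c2ccncc2)s1)C(=O)Nc1c(Cl)cccc1Cl` differs from compound 2 by 2,6-dichlorophenyl in place of 2-chlorobenzyl on an amide-type nitrogen. Among the measured compounds shown here, no measured step covers this change, and the only measured step is unreadable. Compound 3 is expected to stay at the limit, with a step that the limit leaves unreadable from compound 2 to compound 3 estimated as no step beyond the scatter. The estimate for compound 3 is 60000 nM, in a range from 25000 nM to 200000 nM.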

Compound 3, half-maximal cytotoxic concentration: > 50000 nM
Compound 3 ended at the assay's limit; the forecaster's own chance of this, stated with the estimate: 70%; the middle value is on the limit's open side.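

In this assay, among the compounds shown here, compound 2 and compound 3 both stand at the assay's limit, so no step between them can be read. The compounds shown leave open at what concentration any of them becomes cytotoxic, and whether the amide substituent swap changes that.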